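Replacing an ester-bearing side chain on the aniline nitrogen

A few compounds are considered here, and "the series" means these few. Any claim that something is new, unique, unknown or untested is made for them only; others in the source may bear on it.

Of the compounds shown here, three of one family have been tested in a functional assay on DU-145 cells (Homo sapiens) for cytotoxicity, read by trypan blue exclusion, with a stated time of 96 h; a lower number here means a stronger inhibitor, a higher number a weaker inhibitor. Compound 1 `COc1ccc(CS(=O)(=O)/C=C/c2cc(OC)c(OC)cc2OC)cc1N` gives 250 nM, and compound 2 `COc1cc(OC)c(/C=C/S(=O)(=O)Cc2ccc(Br)c(N)c2)c(OC)c1` gives 750 nM. Compound 3 `COC(=O)C(C)(C)Nc1cc(CS(=O)(=O)/C=C/c2c(OC)cc(OC)cc2OC)ccc1OC`, which carries a 1-(methoxycarbonyl)-1-methylethyl group on its aromatic nitrogen, gives 2500 nM, the highest number of the three and therefore the weakest inhibitor among them; its distance from compound 2 and from compound 1 is beyond the usual scatter in both cases.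

Compound 4 `COc1ccc(C(Nc2cc(CS(=O)(=O)/C=C/c3c(OC)cc(OC)cc3OC)ccc2OC)C(=O)O)cc1` has not yet been measured. It differs from compound 3 only at that nitrogen: carboxy(4-methoxyphenyl)methyl in place of 1-(methoxycarbonyl)-1-methylethyl on a nitrogen on an aromatic ring. The change brings in a carboxylic acid and an aromatic ring where the earlier group had an ester and two methyl branches.

Going by the values given here, no measured pair shows what such a change does, so the expectation rests only on the weak number of compound 3 in this assay, 2500 nM, and on the stronger numbers of compound 1 and compound 2. For compound 4 a modest step towards a lower number is expected, a 2.1-fold lower number from compound 3 to compound 4 (0.32 log units; beyond the scatter), though a result within the scatter of compound 3 is also plausible. The estimate for compound 4 in this assay is therefore 1200 nM, with a range from 300 nM to 5000 nM.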

Compound 4, half-maximal inhibitory concentration: 100 nM
Compound 4: the middle estimate sits 12-fold (1.08 log units) above what was measured, outside the stated range (below it).
By their numbers in this assay, from the lowest: compound 4; then compound 1; then compound 2; then compound 3.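

In this assay, the group on this aromatic nitrogen turns out to matter greatly: carboxy(4-methoxyphenyl)methyl in place of 1-(methoxycarbonyl)-1-methylethyl gives a 25-fold lower number from compound 3 to compound 4 (1.40 log units; beyond the scatter), and this is the only pair shown that differs in one place. The larger group, with its aromatic ring and carboxylic acid, is accepted at this nitrogen with a clear gain, so the weak number of compound 3 does not reflect a penalty for every substituent there. No supporting measurement bears on why the number falls.

The pair changes several things at once, an ester for a carboxylic acid and two methyl branches for an aromatic ring, so it cannot show which of these carries the step. Going by these compounds, the methyl ester of compound 4, a side chain with a plain phenyl ring in place of 4-methoxyphenyl, or one with an amide in place of the carboxylic acid would begin to separate these parts, and whether the same gain holds on the cores of compound 1 and compound 2 remains open.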